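A few compounds are considered here, and "the series" means these few. Any claim that something is new, unique, unknown or untested is made for them only; others in the source may bear on it.

Measured in a functional assay on PC-3 cells (Homo sapiens) for antiproliferative activity, read by sulforhodamine B assay, with a stated time of 48 h; a lower number here means a stronger inhibitor of growth, a higher number a weaker inhibitor of growth:
compound 1 `CCCCCCCC/C=C\CCCCCCCC(=O)N1CCCC1`: 13 ug/mL
compound 2 `CCCCCC[C@@H](O)C/C=C\CCCCCCCC(=O)N1CCOCC1`: 38.5 ug/mL
compound 3 `CCCCCCCC/C=C\CCCCCCCC(=O)N1CCCCC1`: 8.7 ug/mL

Compound 3, at 8.7 ug/mL, stands level with compound 1 within the usual scatter, while compound 2 reads clearly higher, at 38.5 ug/mL, a gap beyond the scatter from compound 3.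

The next compound is compound 4 `CCCCCCCC/C=C\CCCCCCCC(=O)N1CCOCC1`. It keeps the chain of compound 3 and has morpholin-4-yl in place of piperidin-1-yl on a carbonyl carbon.

Within the data shown here, only one measured step bears directly on this kind of change. In a 1.5-fold lower number from compound 1 to compound 3 (0.17 log units; within the scatter), piperidin-1-yl replaces pyrrolidin-1-yl on the same carbonyl carbon, and that step stays within the scatter. This suggests that swapping the group at this place need not move the number much, although that step did not introduce morpholin-4-yl. Compound 2, at 38.5 ug/mL, does carry morpholin-4-yl, but on a different chain, so it offers only a weak hint towards a higher number.

The estimated change is a 1.5-fold higher number from compound 3 to compound 4 (0.17 log units; within the scatter), a small upward step that is expected to stay within the scatter in this assay. For compound 4 the expected value is 13 ug/mL, with an estimated range from 6 ug/mL to 30 ug/mL.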

Compound 4, concentration for 50% growth inhibition: 5.2 ug/mL
Beside the measured number, compound 4's estimate is 2.5-fold (0.40 log units) above it, outside the stated range (below it).
By their numbers in this assay, from the lowest: compounds 4, 3 and 1 (each within the scatter of the next, the first and the last beyond it); then compound 2.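

In this assay, morpholin-4-yl on the carbonyl carbon does as well as piperidin-1-yl: the swap gives a 1.7-fold lower number from compound 3 to compound 4 (0.22 log units; within the scatter), so the ring oxygen, with its hydrogen-bond acceptor, brings no change that can be told from the scatter. Against pyrrolidin-1-yl the same group gives a 2.5-fold lower number from compound 1 to compound 4 (0.40 log units; beyond the scatter), a modest step, even though piperidin-1-yl and pyrrolidin-1-yl could not be separated from each other, so the three rings differ only slightly at this place. With morpholin-4-yl held fixed, the hydroxy on the chain is the one remaining difference, and its loss gives a 7.4-fold lower number from compound 2 to compound 4 (0.87 log units; beyond the scatter), which shows that the high number of compound 2 goes with the hydroxy on its chain and not with its ring.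

Nothing measured here explains why the numbers fall as they do.
Going by these compounds, it also remains open whether piperazin-1-yl or an open-chain diethylamino group on the carbonyl carbon would give a number as low as these, and whether a shorter chain would hold it there.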